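The source may hold more compounds than are shown below. What is called first, only, known or untested is meant among the compounds shown, and "the series" means these compounds.

For the measured compounds named here, compound 2 `COc1cc(NC(=O)Nc2cc(Nc3ccc(F)c(Cl)c3)ncn2)cc(OC)c1` stands highest of the two numbers so far in a functional assay on NCI-H520 cells (Homo sapiens) for inhibition, read by MTT assay, with a stated time of 48 h, tested at 10 uM (on this read-out higher numbers stand for more inhibition at the one concentration tested (going by the name of the read-out) and lower numbers for less inhibition), where compound 2 gives 25.5%. Going by the values given here, compound 1 `CCc1ccc(Nc2cc(NC(=O)Nc3cc(OC)cc(OC)c3)ncn2)cc1` gives 23.5% in this assay, and the one measured step between them, a number 2 percentage points higher from compound 1 to compound 2 (within the scatter), changes the same ring that is altered next. Compound 3 `COc1cc(NC(=O)Nc2cc(Nc3ccc(C)c(F)c3)ncn2)cc(OC)c1` carries 3-fluoro-4-methylphenyl in place of 3-chloro-4-fluorophenyl on a nitrogen on an aromatic ring. The expected step is a number 0.5 percentage points lower from compound 2 to compound 3 (within the scatter), because a number 2 percentage points higher from compound 1 to compound 2 (within the scatter) stayed within the scatter when this ring was swapped before. Compound 3 is therefore expected to give about 25%, within a range from 10% to 40%.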

Compound 3, a percentage reported as inhibition, at one concentration (the size of the read-out at that concentration, not a potency): 30.6%
Estimate against measurement, compound 3: 5.6 percentage points below; the range from low to high includes it.
By their numbers in this assay, from the lowest: compounds 1, 2 and 3 (each within the scatter of the next).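

Replacing the chlorine-bearing ring with 3-fluoro-4-methylphenyl on this nitrogen (a number 5.1 percentage points higher from compound 2 to compound 3 (within the scatter)) is a second swap at this place that stays within the scatter, and so does the comparison with the 4-ethylphenyl group (a number 7.1 percentage points higher from compound 1 to compound 3 (within the scatter)). All three substituted phenyl groups therefore read alike in this assay, even across the widest gap so far. No measurement here offers an explanation for these readings.

On these data alone, it remains open whether a phenyl ring carrying an amine or a carboxylic acid would move the number beyond the scatter. The same question applies to a chain longer than ethyl at this place.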